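Azetidin-1-yl added to the pyridin-4-yl of compound 3

The source may report more compounds than this note shows. Statements on the series, on what has been measured and on what is new or still open speak of the compounds shown alone.

Compound 1 `O=C(O)Cc1sc(C(c2ccc(F)cc2)c2ccc(F)cc2)nc1-c1cc(F)cc(F)c1`, compound 2 `O=C(O)Cc1sc(C(c2ccc(F)cc2)c2ccc(F)cc2)nc1-c1ccoc1` and compound 3 `O=C(O)Cc1sc(C(c2ccc(F)cc2)c2ccc(F)cc2)nc1-c1ccncc1` share one core and differ only in the aromatic group attached to it. In an in vitro assay on HEK385-7 cells for displacement of a labelled ligand from prostaglandin D2 receptor 2 (Homo sapiens) (on this read-out higher numbers stand for weaker inhibition and lower numbers for stronger inhibition), compound 1 gives 35 nM, compound 2 gives 14 nM and compound 3 gives 5.3 nM. The two single exchanges bring a 2.5-fold lower number from compound 1 to compound 2 (0.40 log units; beyond the scatter) and a 2.6-fold lower number from compound 2 to compound 3 (0.42 log units; beyond the scatter), and across the pair a 6.6-fold lower number from compound 1 to compound 3 (0.82 log units; beyond the scatter), so compound 3 stands lowest of the three, beyond the scatter from both of the others. Compound 4 `O=C(O)Cc1sc(C(c2ccc(F)cc2)c2ccc(F)cc2)nc1-c1ccnc(N2CCC2)c1` is compound 3 with azetidin-1-yl in place of hydrogen on an aromatic carbon. Going by the values given here, none of the measured steps touches this kind of change: each of them swaps the whole aromatic group, and none adds a substituent onto the pyridin-4-yl that compound 3 carries. Among the compounds with values here, they therefore offer no direct precedent, only the observation that the aromatic group at this place can be varied without losing the activity. For compound 4 the expected step is a 1.1-fold lower number from compound 3 to compound 4 (0.03 log units; within the scatter), that is, no change beyond the scatter. The estimate for compound 4 in this assay is 5 nM, with a range from 1.5 nM to 15 nM.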

Compound 4, half-maximal inhibitory concentration: 660 nM
Beside the measured number, compound 4's estimate is 130-fold (2.12 log units) below it; measured number outside the range, above it.
By their numbers in this assay, from the lowest: compound 3; then compound 2; then compound 1; then compound 4.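

In this assay, the pyridin-4-yl of compound 3 proves far less open to an added substituent than the earlier swaps of the whole aromatic group suggested: azetidin-1-yl next to the ring nitrogen gives a 120-fold higher number from compound 3 to compound 4 (2.10 log units; beyond the scatter), a larger step than any among the first three compounds. The 2-(azetidin-1-yl)pyridin-4-yl group also falls behind both other groups, with a 47-fold higher number from compound 2 to compound 4 (1.67 log units; beyond the scatter) and a 19-fold higher number from compound 1 to compound 4 (1.28 log units; beyond the scatter), so this one addition outweighs the gains seen from replacing 3,5-difluorophenyl. Nothing available here accounts for the loss.

On these data alone, it stays open whether the loss belongs to azetidin-1-yl itself or to any group on this carbon, which a methyl or a dimethylamino group at the same place would help to separate. Also open, as far as these compounds go, is how azetidin-1-yl would fare on another carbon of the pyridin-4-yl.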